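The compounds below may be only part of what the source reports. "The series", "measured", "known", "first", "only" and "open" are said of these compounds alone.

Measured so far in an ADME assay on microsomes from liver (Homo sapiens) for metabolic stability, read by LC-MS, using NADPH, with stated times of 5 min and 30 min, tested at 1 uM; a higher number here means that more of the compound is left, a lower number that less of the compound is left:

Compound 1 `COc1cccc(S(=O)(=O)/C=C/c2ncccc2F)c1` — compound 1 gives 31%
Compound 2 `COc1cccc(S(=O)(=O)/C=C/c2ncccc2Cl)c1` — compound 2 gives 22%
Compound 3 `COc1ccc(S(=O)(=O)/C=C/c2ncccc2F)cc1` — compound 3 gives 1.8%

Compounds 1 and 2 share a core and differ only by chloro in place of fluoro on an aromatic carbon; that step is a number 9 percentage points lower from compound 1 to compound 2 (within the scatter). Compound 3 stands on a different core; how the two cores differ is not broken down here. Compound 3 gives the lowest number of the three, beyond the scatter from both compound 1 and compound 2.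

Compound 4 `COc1ccc(S(=O)(=O)/C=C/c2ncccc2Cl)cc1` is not yet measured. Going by the values given here, it differs from compound 3 by chloro in place of fluoro on an aromatic carbon, the same change as the one from compound 1 to compound 2. Because that earlier step was a number 9 percentage points lower from compound 1 to compound 2 (within the scatter), the step from compound 3 to compound 4 is expected to be small, about a number 0.3 percentage points lower from compound 3 to compound 4 (within the scatter), staying close to the low value of compound 3. Compound 4 is therefore estimated at 1.5%, with a range from 0.3% to 6%.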

Compound 4, percent of the compound remaining: 2%
Beside the measured number, compound 4's estimate is 0.5 percentage points below it; measured number inside the range.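

In this assay chloro in place of fluoro on an aromatic carbon gives a number 0.2 percentage points higher from compound 3 to compound 4 (within the scatter), so the change again leaves no step beyond the scatter. Set beside the earlier step, the new one does not differ from it: the same change on two cores in this assay, a number 9 percentage points lower (within the scatter) from compound 1 to compound 2 and a number 0.2 percentage points higher (within the scatter) from compound 3 to compound 4, 9.2 percentage points apart, within the scatter of two such steps. This shows that the change behaved alike on these two cores, but it does not show that it would do so on a further core, and with compound 3 and compound 4 both so near the bottom of the scale, this core leaves little room for any fall to be seen.

The compounds shown carry only fluoro or chloro at this place, and how a nitrile, a methyl or an amine there would read remains open. Also open, from the compounds shown here alone, is whether a longer chain such as ethoxy in place of methoxy would change the low numbers on the core of compound 3.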